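The compounds below may be only part of what the source reports. "The series", "measured", "known", "first", "only" and "open" are said of these compounds alone.

Measured in a functional assay on ACHN cells (Homo sapiens) for inhibition, read by sulforhodamine B assay, with a stated time of 48 h; on this read-out lower numbers stand for stronger inhibition of growth and higher numbers for weaker inhibition of growth:
- Compound 1 `COc1cc(-c2nn(-c3cccc(NC(=O)Nc4cccc(C(F)(F)F)c4)c3)cc2-c2ccncc2)ccc1Cl`: 3720 nM
- Compound 2 `COc1cc(-c2nn(-c3cccc(NC(=O)c4ccc(Cl)c(C(F)(F)F)c4)c3)cc2-c2ccncc2)ccc1Cl`: > 32500 nM

Compound 2 sits at the limit of > 32500 nM in this assay, at which 1 of the 2 values shown sits, so its result is a limit and not a number. Compound 3 `COc1cc(-c2nn(-c3cccc(NC(=O)c4ccccc4)c3)cc2-c2ccncc2)ccc1Cl` carries phenyl in place of 4-chloro-3-(trifluoromethyl)phenyl on a carbonyl carbon. Going by the values given here, the only measured step at this place, an at least 8.7-fold higher number from compound 1 to compound 2 (0.94 log units; beyond the scatter), is beyond the scatter, but it does not test this change. Compound 3 does not regain the (3-(trifluoromethyl)phenyl)amino group of compound 1, so weak inhibition is expected to persist, with no clear step beyond the scatter. The estimated change is an at least 1.0-fold lower number from compound 2 to compound 3 (0.03 log units; that floor lies within the scatter). For compound 3 the expected value is 30000 nM, with an estimated range of 10000 nM to 60000 nM.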

Compound 3, concentration for total growth inhibition: > 100000 nM
Compound 3 gave a limit, no number; the forecaster's own chance of this, stated with the estimate: 70%; middle value at least 3.3-fold (0.52 log units) away from the limit.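

In this assay phenyl in place of (3-(trifluoromethyl)phenyl)amino on the carbonyl carbon gives an at least 26-fold higher number from compound 1 to compound 3 (1.42 log units; beyond the scatter) and so a second compound without that amino group falls far behind compound 1. Removing the chlorine and the trifluoromethyl group from the ring of compound 2 brings no recovery into a measurable range. Compound 2 and compound 3 both gave limits, and the step between them cannot be read.

Still open, as far as these compounds go, is whether compound 1 depends on the trifluoromethyl group or on the amino link, which a plain phenylamino group on the carbonyl carbon would separate.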